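Adding a methyl to compound 3

This account rests on a few compounds, and the source may have more. Where it says the series, first, only, none or still open, it means among the compounds named here.

In a physicochemical assay for solubility (on this read-out lower numbers stand for lower solubility and higher numbers for higher solubility), compound 3 (`O=S(=O)(NC1CCN(Cc2ccncc2)CC1)c1ccc(-n2cccn2)cc1`) gives 149000 nM, the second highest of three numbers. Compound 1 (`COCCN(C1CCN(Cc2c(-c3ccccc3)[nH]c3c(OC)cccc23)C1)S(C)(=O)=O`) gives 103000 nM, within the scatter of compound 3. Compound 2 (`Cc1cccc2c(CN3CCCC3)c(-c3ccccc3)[nH]c12`) gives 752000 nM, higher than compound 3 and beyond the scatter.

Compound 4 (`Cc1cc(-n2cccn2)ccc1S(=O)(=O)NC1CCN(Cc2ccncc2)CC1`) differs from compound 3 by methyl in place of hydrogen on an aromatic carbon. Going by the values given here, no measured pair shows this change, so the expectation rests on the structural change alone. The expected step is a 1.2-fold lower number from compound 3 to compound 4 (0.08 log units; within the scatter), a small fall within the scatter. For compound 4 the estimated value is 125000 nM, with an expected range of 65000 nM to 230000 nM.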

Compound 4, solubility: 66000 nM
For compound 4 the middle estimate is 1.9-fold (0.28 log units) above the measured one, within the range that was stated.
By their numbers in this assay, from the lowest: compounds 4, 1 and 3 (each within the scatter of the next, the first and the last beyond it); then compound 2.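

Methyl in place of hydrogen on an aromatic carbon, ortho to a large group and meta to the 1H-pyrazol-1-yl group, gives a 2.3-fold lower number from compound 3 to compound 4 (0.35 log units; beyond the scatter) in this assay, so the read-out responds to a change at this position. Going by these compounds alone, this is the only single-place step, so it rests on one pair. Nothing at hand bears on what lies behind the step. On these data alone, whether fluorine, methoxy or ethyl on this carbon would move the number in the same direction remains open, as does the effect of methyl on the other carbons of this ring.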